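Changing the Group on Sulfur in Compound 1

This account rests on a few compounds, and the source may have more. Where it says the series, first, only, none or still open, it means among the compounds named here.

Three related compounds have been tested in an ADME assay on NIH3T3 cells (Mus musculus) for cytotoxicity, read by MTT assay, with a stated time of 24 h; on this read-out higher numbers stand for weaker inhibition and lower numbers for stronger inhibition. Compound 1 `N#Cc1ccc(-c2cs/c(=N/NC(=O)CSc3ncccn3)n2-c2ccccc2)cc1` gives < 3.9 ug/mL, which is a limit of the assay rather than a number. Compound 2 `O=C(CSc1ncccn1)N/N=c1/scc(-c2ccc(Cl)cc2)n1-c1ccccc1` gives 397 ug/mL in this assay. Compound 3 `COc1ccc(-c2cs/c(=N/NC(=O)CSc3ncccn3)n2-c2ccccc2)cc1` gives 450 ug/mL. The step of an at least 100-fold higher number from compound 1 to compound 2 (2.00 log units; beyond the scatter) and the step of an at least 110-fold higher number from compound 1 to compound 3 (2.06 log units; beyond the scatter) both lie beyond the scatter, while the step of a 1.1-fold higher number from compound 2 to compound 3 (0.05 log units; within the scatter) does not. Compound 1 therefore stands at the lower edge of the numbers shown, at a limit, and it is the compound with the cyano group.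

Compound 4 `N#Cc1ccc(-c2cs/c(=N/NC(=O)CSc3nnnn3-c3ccccc3)n2-c2ccccc2)cc1` keeps that cyano group and differs from compound 1 only at the sulfur: 1-phenyl-1H-tetrazol-5-yl in place of pyrimidin-2-yl on a sulfur. Going by the values given here, none of the measured steps touches this sulfur; all three concern the group on the aromatic carbon, so they give no direct guide to the size of this step. Since compound 1 sits at the limit of < 3.9 ug/mL in this assay, at which 1 of the 3 values shown sits, the expectation for compound 4 rests on that limit and on the retained cyano group. The step of an at least 1.2-fold higher number from compound 1 to compound 4 (0.10 log units; that floor lies within the scatter) is expected to be small, with its direction uncertain. Compound 4 is expected to give about 5 ug/mL in this assay, estimated to lie between 1 ug/mL and 50 ug/mL.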

Compound 4, half-maximal inhibitory concentration: 453 ug/mL
Compound 4: the middle estimate sits 91-fold (1.96 log units) below what was measured, outside the stated range (above it).
By their numbers in this assay, from the lowest: compounds 2, 3 and 4 (each within the scatter of the next). At a limit, below all of these: compound 1.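

At the sulfur, 1-phenyl-1H-tetrazol-5-yl in place of pyrimidin-2-yl gives an at least 110-fold higher number from compound 1 to compound 4 (2.06 log units; beyond the scatter) in this assay. Compound 4 keeps the cyano group of compound 1, so holding that group in place is not enough to keep the number low, and the group on the sulfur counts as well. The value of compound 1 is a limit, so the true size of this step stays unknown and only its floor can be read: the limit of < 3.9 ug/mL in this assay, at which 1 of the 4 values shown sits.

The compounds shown leave open which part of the entering group goes with the higher number, the five-membered ring or its phenyl, and a plain phenyl or a pyridin-2-yl on the sulfur would help separate the two. Also open, from the compounds shown here alone, is whether a smaller group on the sulfur, such as methyl, would keep the low number of compound 1.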